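Bromo in place of chloro in compound 2

This account rests on a few compounds, and the source may have more. Where it says the series, first, only, none or still open, it means among the compounds named here.

Of the compounds shown here, two have been measured so far in a functional assay, with a stated time of 6 min; on this read-out lower numbers stand for stronger inhibition and higher numbers for weaker inhibition.
- compound 1 `Fc1cc(NCn2nc(-c3ccc4c(c3)OCCO4)oc2=S)cc(F)c1F` gives 2920 nM
- compound 2 `S=c1oc(-c2ccc3c(c2)OCCO3)nn1CNc1cccc(Cl)c1` gives 6220 nM

Compound 2 has the higher number of the two, so it is the weaker inhibitor here. Compound 3 `S=c1oc(-c2ccc3c(c2)OCCO3)nn1CNc1cccc(Br)c1` carries bromo in place of chloro on an aromatic carbon. Within the data shown here, the one measured step that bears on this is modest: a 2.1-fold higher number from compound 1 to compound 2 (0.33 log units; beyond the scatter). It swaps 3,4,5-trifluorophenyl for 3-chlorophenyl, a larger change, and no direct chloro-to-bromo swap has been measured. Little movement is therefore expected in this assay, with no step beyond the scatter. The expected change is a 1.1-fold lower number from compound 2 to compound 3 (0.05 log units; within the scatter). For compound 3 the estimate is 5500 nM, with an expected range from 2800 nM to 11000 nM.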

Compound 3, half-maximal inhibitory concentration: 10800 nM
Estimate against measurement, compound 3: 2.0-fold (0.29 log units) below, and the stated range covers the measured number.
By their numbers in this assay, from the lowest: compound 1; then compounds 2 and 3 (each within the scatter of the next).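

In this assay the direct swap of chloro for bromo on this aromatic carbon gives a 1.7-fold higher number from compound 2 to compound 3 (0.24 log units; within the scatter) and so does not separate the two halogens. Replacing 3,4,5-trifluorophenyl with 3-bromophenyl gives a 3.7-fold higher number from compound 1 to compound 3 (0.57 log units; beyond the scatter) and this step, unlike the swap of the two halogens, is a real difference, matching what 3-chlorophenyl showed. No available evidence explains either result. On these data alone, what a methoxy group or a nitrile would do on this aromatic carbon stays open, as does the effect of a single fluoro there.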